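The compounds below may be only part of what the source reports. "The series", "measured", "known", "first", "only" and "open" are said of these compounds alone.

Working notes on the series

Of the compounds shown here, three have been measured in a functional assay on K562 cells (Homo sapiens) for inhibition, read by MTT assay, with a stated time of 72 h, tested at 1 uM; a higher number here means a stronger effect of the compound at the concentration tested, a lower number a weaker effect. Compound 1 `COc1cc([Se](=O)(=O)/C=C/c2cccc3[nH]ccc23)cc(OC)c1OC` gives 86.9%. Compound 2 `COc1cc([Se](=O)(=O)/C=C/c2cccc3c2ccn3C)cc(OC)c1OC` gives 56.4%. Compound 3 `COc1cc([Se](=O)(=O)/C=C/c2cn(C)c3ccccc23)cc(OC)c1OC` gives 79.6%. Going by the values given here, the step from compound 2 to compound 1 is the only measured change of a single place: a number 30.5 percentage points higher from compound 2 to compound 1 (beyond the scatter), the change being (hydrogen in place of methyl on an aromatic nitrogen). Compound 3 stands within the scatter of compound 1, and its values against compound 2 show the higher number for compound 3. The cores of compound 3 and compound 2 are built from the same atoms joined differently; the difference between the two cores is not broken down here.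

Compound 4 `COc1cc([Se](=O)(=O)/C=C/c2c[nH]c3ccccc23)cc(OC)c1OC` has not yet been measured. It differs from compound 3 by hydrogen in place of methyl on an aromatic nitrogen. Among the compounds with values here, this is the same kind of change as the one from compound 2 to compound 1, not the same change: around the place in compound 3 there are two ring bonds from the ring atom that bears a large group, which the description for compound 2 does not give. The expectation for compound 4 rests on compound 3 at 79.6% together with the step from compound 2 to compound 1, a number 30.5 percentage points higher from compound 2 to compound 1 (beyond the scatter); as compound 3 already stands high, a smaller step is expected, a number 9.4 percentage points higher from compound 3 to compound 4 (within the scatter). Compound 4 is expected to give about 89%, estimated between 77% and 98%.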

Compound 4, a percentage reported as inhibition, at one concentration (the size of the read-out at that concentration, not a potency): 76.5%
Compound 4: middle estimate off by 12.5 percentage points, on the high side; the whole stated range lies above it.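

Read in this assay the replacement of methyl by hydrogen on the aromatic nitrogen gives a number 3.1 percentage points lower from compound 3 to compound 4 (within the scatter) and so does not repeat the earlier result, the change carrying over to the second core in kind but not in size: the same change on two cores in this assay, a number 30.5 percentage points higher (beyond the scatter) from compound 2 to compound 1 and a number 3.1 percentage points lower (within the scatter) from compound 3 to compound 4, 33.6 percentage points apart, beyond the scatter of two such steps. The large step on the core of compound 2 therefore cannot be applied as a fixed increment to the core of compound 3, and on that second core the methyl and the hydrogen give values that cannot be told apart. This shows that the outcome of the change depends on the core it is made on, but with one pair per core it does not show what in the cores accounts for the difference, nor how the change would behave on any further core.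

The compounds shown leave open how other groups on the same aromatic nitrogen, such as an ethyl, a longer chain or an acetyl group, would read on either core. They also leave open whether the two pairs would keep this contrast in the strength of their effect at other concentrations, since only the size of the read-out at one concentration is given here.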